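The source may hold more compounds than are shown below. What is called first, only, known or untested is meant among the compounds shown, and "the series" means these compounds.

Working notes on the shared core.

Compound 1 `O=C([C@@H]1CCCN1)N1CCC2(CCN(c3nccc(NCc4ccc(Cl)cc4Cl)n3)CC2)C1` carries a (pyrrolidin-2-yl)carbonyl group on the amide-type nitrogen in the ring. Among the measured compounds shown here, in a physicochemical assay for solubility, read by chemiluminescence, measured as kinetic solubility (a higher number here means a more soluble compound, a lower number a less soluble compound), compound 1 gives 165 ug/mL, the lowest of the two numbers measured so far. Compound 2 `O=C([C@@H]1CCCCN1)N1CCC2(CCN(c3nccc(NCc4ccc(Cl)cc4Cl)n3)CC2)C1` gives 170 ug/mL in this assay; the change from compound 1 to compound 2 reads a 1.0-fold higher number from compound 1 to compound 2 (0.01 log units; within the scatter), so the two values are indistinguishable.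

Compound 3 `O=C(c1ccccn1)N1CCC2(CCN(c3nccc(NCc4ccc(Cl)cc4Cl)n3)CC2)C1` is not yet measured. Its difference from compound 1 is pyridin-2-yl in place of pyrrolidin-2-yl on a carbonyl carbon. For the measured compounds named here, the only measured step, a 1.0-fold higher number from compound 1 to compound 2 (0.01 log units; within the scatter), swaps one saturated ring for another of the same kind and keeps the hydrogen-bond donor; it bears only loosely on the step to compound 3, which removes that donor and brings in an aromatic ring. Going by the values given here, no measured pair mirrors that change, so the expectation rests on the structural difference alone.

For compound 3 the number in this assay is expected to come out lower than for compound 1, estimated at 40 ug/mL with a range of 10 ug/mL to 130 ug/mL. That estimate means an expected step of a 4.1-fold lower number from compound 1 to compound 3 (0.62 log units; beyond the scatter) from compound 1 to compound 3.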

Compound 3, solubility: 17 ug/mL
Compound 3: the middle estimate sits 2.4-fold (0.37 log units) above what was measured; the range from low to high includes it.
By their numbers in this assay, from the lowest: compound 3; then compounds 1 and 2 (each within the scatter of the next).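

On the carbonyl carbon, this assay does separate the groups once an aromatic ring enters: pyridin-2-yl in place of pyrrolidin-2-yl gives a clear drop (a 9.7-fold lower number from compound 1 to compound 3 (0.99 log units; beyond the scatter)), and pyridin-2-yl in place of piperidin-2-yl gives another (a 10-fold lower number from compound 2 to compound 3 (1.00 log units; beyond the scatter)). The earlier step between the two saturated rings showed no such separation, so this position is not indifferent to its substituent, and in these three compounds ring size alone is not what separates the numbers. No measurement on hand accounts for the drop, and the swap changes the ring's aromaticity and its hydrogen-bond donor count together, so the data cannot assign the step to either.

The compounds shown leave open how a phenyl ring, a cyclohexyl ring, an open-chain amine or a carboxylic acid on the same carbonyl carbon would read in this assay, which is what would pull the two structural differences apart. They also leave open whether a step of this size would hold with the (pyridin-2-yl)carbonyl group on a core other than the shared one.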